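Amide substituent: hydroxyethyl replaces isopropyl on the carbamoyl

The source may report more compounds than this note shows. Statements on the series, on what has been measured and on what is new or still open speak of the compounds shown alone.

Compound 3 `CC[C@H]1CN(c2ncc(C(=O)NC(C)C)nc2Cl)CCN1C1CCN(C(=O)c2ccc(Cl)nc2N)CC1` has the lowest number of the three measured in an in vitro assay on BaF3 cells for displacement of a labelled ligand from C-X-C chemokine receptor type 3 (Homo sapiens) (on this read-out lower numbers stand for stronger inhibition and higher numbers for weaker inhibition), giving 0.9 nM. Compound 1 `CC[C@H]1CN(c2ncc(C(N)=O)nc2Cl)CCN1C1CCN(C(=O)c2ccc(Cl)nc2N)CC1` gives 2.5 nM and compound 2 `CC[C@H]1CN(c2ncc(C(=O)NC(C)(C)C)nc2Cl)CCN1C1CCN(C(=O)c2ccc(Cl)nc2N)CC1` gives 1.5 nM; the steps are a 2.8-fold lower number from compound 1 to compound 3 (0.44 log units; beyond the scatter), a 1.7-fold lower number from compound 1 to compound 2 (0.22 log units; within the scatter) and a 1.7-fold lower number from compound 2 to compound 3 (0.22 log units; within the scatter). Compound 4 `CC[C@H]1CN(c2ncc(C(=O)NCCO)nc2Cl)CCN1C1CCN(C(=O)c2ccc(Cl)nc2N)CC1` is not yet measured; it differs from compound 3 by 2-hydroxyethyl in place of isopropyl on an amide-type nitrogen. The measured steps concern alkyl groups of similar size on this nitrogen, and none of them tests a hydroxyl on it, so they bear only loosely on the new change. The expectation for compound 4 is therefore a step of about a 1.7-fold higher number from compound 3 to compound 4 (0.22 log units; within the scatter) in this assay, not beyond the scatter. Compound 4 is estimated at 1.5 nM, within 0.6 nM to 4 nM.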

Compound 4, half-maximal inhibitory concentration: 2.9 nM
Beside the measured number, compound 4's estimate is 1.9-fold (0.29 log units) below it, and the stated range covers the measured number.
By their numbers in this assay, from the lowest: compounds 3, 2, 1 and 4 (each within the scatter of the next, the first and the last beyond it).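

In this assay 2-hydroxyethyl on the amide-type nitrogen gives a step beyond the scatter relative to isopropyl (a 3.2-fold higher number from compound 3 to compound 4 (0.51 log units; beyond the scatter)), so this substituent change does register at this position. Relative to the other two substituents the steps stay within the scatter (a 1.9-fold higher number from compound 2 to compound 4 (0.29 log units; within the scatter); a 1.2-fold higher number from compound 1 to compound 4 (0.06 log units; within the scatter)), which leaves 2-hydroxyethyl unseparated from tert-butyl or the unsubstituted amide. Nothing available accounts for the step from isopropyl. As far as these compounds go, it remains open whether the hydroxyl or the loss of isopropyl matters more, which an n-propyl group could help separate. From the compounds shown here alone, how an amine, a carboxylic acid or a longer hydroxyalkyl chain would fare on this nitrogen is also open.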